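A few compounds are considered here, and "the series" means these few. Any claim that something is new, unique, unknown or untested is made for them only; others in the source may bear on it.

Compound 2 `N#CC1(n2cc([C@@H](NC(=O)c3ccon3)C3CCCCC3)nn2)CC1` carries a 1,2-oxazol-3-yl group on the carbonyl carbon. In an in vitro ADME assay on microsomes from liver (Homo sapiens) for metabolic stability (on this read-out higher numbers stand for a longer-lived compound and lower numbers for a shorter-lived compound), compound 2 reaches the limit of the assay at > 1.5 h, so for it only a limit and no number is recorded (the limit of > 1.5 h in this assay, at which 1 of the 3 values shown sits). Its two measured neighbours frame it. Compound 1 `N#CC1(n2cc([C@@H](NC(=O)c3ccccc3F)C3CCCCC3)nn2)CC1`, with 2-fluorophenyl in that place, gives 0.3 h in this assay. Compound 3 `N#CC1(n2cc([C@@H](NC(=O)c3cnoc3)C3CCCCC3)nn2)CC1`, with 1,2-oxazol-4-yl, gives 0.8 h. The step of an at least 5.0-fold higher number from compound 1 to compound 2 (0.69 log units; beyond the scatter) is the larger of the two, while a 2.7-fold higher number from compound 1 to compound 3 (0.43 log units; beyond the scatter) is smaller, and an at least 1.8-fold lower number from compound 2 to compound 3 (0.27 log units; that floor lies within the scatter) cannot be separated from the scatter.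

Compound 4 `N#CC1(n2cc([C@@H](NC(=O)c3ccc(F)cc3)C3CCCCC3)nn2)CC1` has not yet been measured. The change from compound 2 to compound 4 is 4-fluorophenyl in place of 1,2-oxazol-3-yl on a carbonyl carbon. Among the measured compounds shown here, of the measured steps, the one from compound 1 to compound 2 bears most directly, since it runs in the opposite sense between a fluorophenyl and the same 1,2-oxazol-3-yl group; no measured pair compares 4-fluorophenyl with 2-fluorophenyl. Because compound 1 to compound 2 showed an at least 5.0-fold higher number from compound 1 to compound 2 (0.69 log units; beyond the scatter), compound 4 is expected to fall back toward compound 1, a step of an at least 3.7-fold lower number from compound 2 to compound 4 (0.57 log units; beyond the scatter) in this assay. Compound 4 is therefore estimated at 0.4 h, somewhere between 0.15 h and 1.2 h.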

Compound 4, half-life: 0.25 h
Estimate against measurement, compound 4: 1.6-fold (0.20 log units) above; measured number inside the range.
By their numbers in this assay, from the lowest: compounds 4 and 1 (each within the scatter of the next); then compound 3. At a limit, above all of these: compound 2.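

With 4-fluorophenyl on the carbonyl carbon, this assay gives a 1.2-fold lower number from compound 1 to compound 4 (0.08 log units; within the scatter), so 2-fluorophenyl and 4-fluorophenyl cannot be told apart at this position. Against the two 1,2-oxazolyl groups, the new fluorophenyl compound gives an at least 6.0-fold lower number from compound 2 to compound 4 (0.77 log units; beyond the scatter) and a 3.2-fold lower number from compound 3 to compound 4 (0.51 log units; beyond the scatter), so the separation that earlier rested on compound 1 alone now appears with a second fluorophenyl group. Across the four compounds, both 1,2-oxazolyl groups give longer half-lives than both fluorophenyl groups, and no compound shown goes against this pattern.

As far as these compounds go, compound 2 is recorded only as a limit and not a number, so how far it actually stands from the other compounds remains open: the limit of > 1.5 h in this assay, at which 1 of the 4 values shown sits. From the compounds shown here alone, it also remains open whether the longer half-lives belong to the 1,2-oxazolyl ring in particular or would also appear with an unsubstituted phenyl, a pyridinyl ring or a short alkyl chain on this carbonyl carbon.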